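Aryl swap at the thiazolidine-adjacent carbon of an octadecyl amide series

The compounds below may be only part of what the source reports. "The series", "measured", "known", "first", "only" and "open" are said of these compounds alone.

Of the compounds shown here, two have been measured so far in a functional assay on PC-3 cells (Homo sapiens) for antiproliferative activity, read by sulforhodamine B assay; a higher number here means a weaker inhibitor, a lower number a stronger inhibitor. Compound 1 `CCCCCCCCCCCCCCCCCCNC(=O)[C@H]1CSC(Cc2ccccc2)N1` gives 16400 nM. Among the compounds with values here, compound 2 `CCCCCCCCCCCCCCCCCCNC(=O)[C@H]1CSC(c2c[nH]c3ccccc23)N1` gives 11500 nM, the only other number; the step of a 1.4-fold lower number from compound 1 to compound 2 (0.15 log units; within the scatter) is the single measured change at this position and separates compound 2 from compound 1 by less than the scatter. Compound 3 `CCCCCCCCCCCCCCCCCCNC(=O)[C@H]1CSC(c2cccc(O)c2)N1` is the next compound: 3-hydroxyphenyl in place of 1H-indol-3-yl on a saturated ring carbon. Within the data shown here, the only step that bears on this change is a 1.4-fold lower number from compound 1 to compound 2 (0.15 log units; within the scatter), which exchanged one aryl group for another at the same ring carbon without moving the number beyond the scatter. On that basis no step beyond the scatter is expected for the present aryl exchange, and the number for compound 3 in this assay is estimated at 12000 nM, within 4000 nM to 40000 nM, which corresponds to an expected step of a 1.0-fold higher number from compound 2 to compound 3 (0.02 log units; within the scatter).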

Compound 3, half-maximal inhibitory concentration: 6700 nM
Beside the measured number, compound 3's estimate is 1.8-fold (0.25 log units) above it, and the stated range covers the measured number.
By their numbers in this assay, from the lowest: compounds 3, 2 and 1 (each within the scatter of the next, the first and the last beyond it).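

In this assay, within the data shown here, the 3-hydroxyphenyl group provides the first step at this saturated ring carbon that clears the scatter: a 2.4-fold lower number from compound 1 to compound 3 (0.39 log units; beyond the scatter), a modest separation. Against the 1H-indol-3-yl group the picture is different, with a 1.7-fold lower number from compound 2 to compound 3 (0.23 log units; within the scatter), so exchanging the two-ring group for one six-membered aromatic ring of carbon only leaves the two compounds unresolved. No measured evidence is available to explain either step.

From the compounds shown here alone, it remains open whether the hydroxyl group contributes to the separation from compound 1, and a plain phenyl or a 3-aminophenyl group at the same carbon would test this against compound 3. Also open, going by these compounds, is how far these numbers depend on the octadecyl chain, which a shorter alkyl chain on the amide nitrogen would address.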